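A few compounds are considered here, and "the series" means these few. Any claim that something is new, unique, unknown or untested is made for them only; others in the source may bear on it.

Compound 2 `Cc1nc(N[C@@H]2C[C@H]3CC[C@@H]2C3)c2cc(-c3ccc(Cl)c(Cl)c3)ccc2n1` carries a 3,4-dichlorophenyl group on the shared core. In a functional assay for positive allosteric modulation of GABA-B receptor (Homo sapiens), read by GTPgammaS binding (a higher number here means that more compound is needed for the effect, a lower number that less compound is needed), compound 2 gives 419 nM. Among the measured compounds shown here, only one other number exists so far: compound 1 `Cc1nc(N[C@@H]2C[C@H]3CC[C@@H]2C3)c2cc(-c3ccccc3Cl)ccc2n1`, which carries a 2-chlorophenyl group instead, gives 496 nM in this assay, and the two numbers lie within the scatter of each other. Compound 3 `Cc1nc(N[C@@H]2C[C@H]3CC[C@@H]2C3)c2cc(-c3cc(Cl)cc(Cl)c3)ccc2n1` has not yet been measured. It differs from compound 2 in one place: 3,5-dichlorophenyl in place of 3,4-dichlorophenyl on an aromatic carbon. For the measured compounds named here, the only measured step that bears on this change is a 1.2-fold lower number from compound 1 to compound 2 (0.07 log units; within the scatter), which shows that rearranging the chlorine pattern on the chlorophenyl group left the number essentially where it was. A similar outcome is therefore expected here, with no step beyond the scatter. On that basis compound 3 is expected to give 450 nM, with a range from 200 nM to 1000 nM, which corresponds to an expected step of a 1.1-fold higher number from compound 2 to compound 3 (0.03 log units; within the scatter).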

Compound 3, half-maximal effective concentration: 97 nM
Compound 3: the middle estimate sits 4.6-fold (0.67 log units) above what was measured; the whole stated range lies above it.
By their numbers in this assay, from the lowest: compound 3; then compounds 2 and 1 (each within the scatter of the next).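

The two compounds have the same atoms, yet the change to 3,5-dichlorophenyl brings a 4.3-fold lower number from compound 2 to compound 3 (0.64 log units; beyond the scatter) in this assay, so this position does respond to where the chlorines sit on the phenyl ring, something the step between the two earlier compounds, which lay within the scatter, gave no sign of. Compared with the 2-chlorophenyl group, the same group brings a 5.1-fold lower number from compound 1 to compound 3 (0.71 log units; beyond the scatter), which sets the 3,5-dichlorophenyl pattern apart from both others shown. Nothing available explains why this arrangement gives the lower number.

From the compounds shown here alone, all three compounds carry only chlorine on this phenyl ring, so whether fluorine, a methyl group or an amine in the same places would give a similar number stays open. Going by these compounds, it also stays open whether the 3,5-dichlorophenyl pattern would keep its advantage with a different group on the nitrogen of the shared core.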